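Trimming a methyl from the carbamate of compound 3

The compounds below may be only part of what the source reports. "The series", "measured", "known", "first", "only" and "open" are said of these compounds alone.

Three compounds sharing a fused core carrying the same fluorinated methylsulfonylphenyl group have been measured in a functional assay on CHO-K1 cells for agonist activity at Glucose-dependent insulinotropic receptor (Homo sapiens), read by a luciferase reporter, with a stated time of 5 h; a higher number here means that more compound is needed for the effect, a lower number that less compound is needed. Compound 1, `CCS(=O)(=O)N1CCC(Oc2ncnc3c2CCN3c2ccc(S(C)(=O)=O)cc2F)CC1`, gives 1580 nM. Compound 2, `CC(C)S(=O)(=O)N1CCC(Oc2ncnc3c2CCN3c2ccc(S(C)(=O)=O)cc2F)CC1`, gives 1260 nM. These two differ only by hydrogen in place of methyl on a saturated chain carbon bound to a saturated chain carbon and a sulfonyl sulfur, and the step of a 1.3-fold higher number from compound 2 to compound 1 (0.10 log units; within the scatter) shows that removing this methyl left the number essentially unchanged. Compound 3, `Cc1nc(OC2CCN(C(=O)OC(C)(C)C)CC2)c2c(n1)N(c1ccc(S(C)(=O)=O)cc1F)CC2`, carries a tert-butoxycarbonyl group on the piperidine nitrogen and a methyl on its core; it gives 126 nM, the lowest of the three numbers, with both compound 1 and compound 2 lying beyond the scatter above it. How the core of compound 3 differs from that of compound 2 is not broken down here.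

Compound 4, `Cc1nc(OC2CCN(C(=O)OC(C)C)CC2)c2c(n1)N(c1ccc(S(C)(=O)=O)cc1F)CC2`, has not yet been measured. It differs from compound 3 by hydrogen in place of methyl on a saturated chain carbon bound to an oxygen next to a carbonyl group and two saturated chain carbons. Going by the values given here, this is the same kind of change as the one from compound 2 to compound 1, but not the same: there the carbon losing its methyl sat bound to a saturated chain carbon and a sulfonyl sulfur, here it sits bound to an oxygen next to a carbonyl group and two saturated chain carbons. Among the compounds with values here, because the only measured instance, a 1.3-fold higher number from compound 2 to compound 1 (0.10 log units; within the scatter), stayed within the scatter, compound 4 is expected to give a number close to that of compound 3, the step estimated at a 1.6-fold higher number from compound 3 to compound 4 (0.20 log units; within the scatter). Compound 4 is therefore estimated at 200 nM, in the range 90 nM to 450 nM.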

Compound 4, half-maximal effective concentration: 100 nM
Compound 4: the middle estimate sits 2.0-fold (0.30 log units) above what was measured, and the stated range covers the measured number.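

In this assay, the change from tert-butoxycarbonyl to isopropoxycarbonyl gave a 1.3-fold lower number from compound 3 to compound 4 (0.10 log units; within the scatter), so taking away this methyl again left the number essentially unchanged. Set beside the earlier case, the two steps agree: the same change on two cores in this assay, a 1.3-fold higher number (0.10 log units; within the scatter) from compound 2 to compound 1 and a 1.3-fold lower number (0.10 log units; within the scatter) from compound 3 to compound 4, 1.6-fold (0.20 log units) apart, within the scatter of two such steps This shows that hydrogen in place of methyl made no difference beyond the scatter in either of these two settings, even though the carbon losing its methyl is bound to a sulfonyl sulfur in one and to an oxygen next to a carbonyl group in the other; it does not show that the change would be as quiet on any other core in the series, and with both steps inside the scatter it gives no direction for the change.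

The compounds shown leave open how much of the distance between compound 3 and the two sulfonyl compounds belongs to the core and how much to the carbamate, as the carbamate is seen only on the core of compound 3 and the sulfonyl groups only on the other core. They also leave open whether the number would hold with a shorter ethoxycarbonyl group, a cyclopropoxycarbonyl group or an amide in the same place.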